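Methoxy added to compound 1: working notes on the series

A few compounds are considered here, and "the series" means these few. Any claim that something is new, unique, unknown or untested is made for them only; others in the source may bear on it.

Measured in a functional assay on RPMI cells (Homo sapiens); a lower number here means that less compound is needed, a higher number that more compound is needed for the effect:
- compound 1 `COc1cc2sc(-c3ccccc3)cc(=O)c2cc1OC` gives 8.89 ug/mL
- compound 2 `O=c1cc(-c2ccccc2)sc2cc(O)c(O)cc12` gives 3.92 ug/mL
- compound 3 `CC(=O)Oc1cc2sc(-c3ccccc3)cc(=O)c2cc1OC(C)=O` gives 5.5 ug/mL

Compound 1 and compound 3 lie within the scatter of each other. Only compound 2 stands lower than compound 1, and that gap is beyond the scatter.

Compound 4 `COc1cccc(-c2cc(=O)c3cc(OC)c(OC)cc3s2)c1` differs from compound 1 by methoxy in place of hydrogen on an aromatic carbon. Among the measured compounds shown here, no measured pair isolates a change at this place, so no step beyond the scatter is expected in this assay. The estimated step of a 1.1-fold lower number from compound 1 to compound 4 (0.05 log units; within the scatter) is small, with little evidence to narrow it. Compound 4 is estimated at 8 ug/mL (expected range 3.5 ug/mL to 18 ug/mL).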

Compound 4, concentration for half-maximal effect: 5.5 ug/mL
Beside the measured number, compound 4's estimate is 1.5-fold (0.16 log units) above it; the range from low to high includes it.
By their numbers in this assay, from the lowest: compounds 2, 3, 4 and 1 (each within the scatter of the next, the first and the last beyond it).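

In this assay the step of a 1.6-fold lower number from compound 1 to compound 4 (0.21 log units; within the scatter) shows that methoxy in place of hydrogen on an aromatic carbon, meta to a large group, leaves the number within the scatter. Among the compounds shown here, this is the first measured change on this six-membered aromatic ring of carbon only, as the earlier compounds differ elsewhere. No available data bear on a cause for this step.

Going by these compounds, whether an amine or a carboxylic acid at this place would also stay within the scatter remains open. So does the outcome of methoxy on the ring's other carbons.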